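Swapping One Group on a Sulfonyl Sulfur

The compounds below may be only part of what the source reports. "The series", "measured", "known", "first", "only" and "open" are said of these compounds alone.

Within the data shown here, in an ADME assay on microsomes from liver (Homo sapiens) for metabolic stability, read by LC-MS, with a stated time of 30 min, tested at 1 uM (a higher number here means that more of the compound is left, a lower number that less of the compound is left), compound 2 `O=C(NCc1ccc(S(=O)(=O)c2ccccc2C(F)(F)F)cc1)c1cc2cnccc2[nH]1` gives 52%, the lowest of the three numbers measured so far. Compound 3 `O=C(NCc1ccc(S(=O)(=O)N2CCCCC2)cc1)c1cnc2nccn2c1` gives 64%, which is the nearest value but still higher by more than the usual scatter. Compound 1 `O=C(NCc1ccc(S(=O)(=O)c2ccccc2)cc1)c1ccc2nccn2c1` gives 77%, the furthest from compound 2.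

The next molecule, compound 4 `Cc1cccc(S(=O)(=O)c2ccc(CNC(=O)c3cc4cnccc4[nH]3)cc2)c1`, keeps the core of compound 2 and changes one group: 3-methylphenyl in place of 2-(trifluoromethyl)phenyl on a sulfonyl sulfur. In words, 3-methylphenyl stands in place of 2-(trifluoromethyl)phenyl on a sulfonyl sulfur.

Among the measured compounds shown here, no measured pair here differs in only one place, so the data do not show directly what such a swap does. The closest guide is compound 2 itself, and its 52% serves as the starting point. The expected change in this assay is small and downward, a number 6 percentage points lower from compound 2 to compound 4 (within the scatter), and it may not exceed the scatter. The estimate for compound 4 is 46%, with an expected range from 26% to 66%.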

Compound 4, percent of the compound remaining: 49%
For compound 4 the middle estimate is 3 percentage points below the measured one; measured number inside the range.
By their numbers in this assay, from the lowest: compounds 4 and 2 (each within the scatter of the next); then compound 3; then compound 1.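

Among these compounds, this is the first pair that differs in one place only, and in this assay putting 3-methylphenyl in place of 2-(trifluoromethyl)phenyl on a sulfonyl sulfur gives a number 3 percentage points lower from compound 2 to compound 4 (within the scatter). At this position on the core of compound 2, then, the 10 heavy atoms of the leaving group, 3 of them fluorine, can give way to the 7 carbon atoms of the entering group with no difference beyond the scatter in the percent of compound remaining. Nothing available explains this result.

Both groups are phenyl rings that carry a single group, so a phenyl ring carrying an amine or a carboxylic acid on the same sulfur remains an open case. Going by these compounds, whether this swap would read the same on the core of compound 1 is also open.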